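Adding one fluoro to compound 2

The compounds below may be only part of what the source reports. "The series", "measured", "known", "first", "only" and "open" are said of these compounds alone.

Measured so far in a functional assay on Jurkat cells (Homo sapiens) (on this read-out higher numbers stand for weaker inhibition and lower numbers for stronger inhibition), are two compounds:
Compound 1 `CC(C)[C@H](NC(=O)COc1cccc2ccccc12)C(=O)N[C@@H](CC(=O)O)C(=O)COc1ccccc1[N+](=O)[O-]` gives > 100000 nM as a limit of the assay
Compound 2 `CC(C)[C@H](NC(=O)COc1cccc2ccccc12)C(=O)N[C@@H](CC(=O)O)C(=O)COc1ccc(F)cc1F` gives 33200 nM as a number

Among the measured compounds shown here, compound 2 at 33200 nM holds the only true number so far. Compound 3 `CC(C)[C@H](NC(=O)COc1cccc2ccccc12)C(=O)N[C@@H](CC(=O)O)C(=O)COc1ccc(F)c(F)c1F` differs from it by fluoro in place of hydrogen on an aromatic carbon in a fluoro in place of hydrogen on an aromatic carbon. For the measured compounds named here, the one measured step of an at least 3.0-fold lower number from compound 1 to compound 2 (0.47 log units; beyond the scatter) exchanged a whole group and bears only loosely on this smaller change. In this assay no step beyond the scatter is therefore expected. The expected step is a 1.2-fold lower number from compound 2 to compound 3 (0.07 log units; within the scatter) in this estimate. Compound 3 is expected at 28000 nM with an estimated range from 9000 nM to 90000 nM in this assay.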

Compound 3, half-maximal inhibitory concentration: 35800 nM
Beside the measured number, compound 3's estimate is 1.3-fold (0.11 log units) below it; the range from low to high includes it.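

In this assay, a fluoro on the aromatic carbon ortho to two fluoro groups leaves the read-out unmoved, with a 1.1-fold higher number from compound 2 to compound 3 (0.03 log units; within the scatter). The advantage over the 2-nitrophenyl group therefore persists with the 2,3,4-trifluorophenyl group, with an at least 2.7-fold lower number from compound 1 to compound 3 (0.44 log units; beyond the scatter). This comparison rests on a value for compound 1 that is a limit of the assay: the limit of > 100000 nM in this assay, at which 1 of the 3 values shown sits.

On these data alone, what a methoxy group or an amine on this carbon would do remains open. So does the effect of a fluoro here on a ring without the other two fluoro groups.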